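Moving the Chlorine Around the Sulfonyl Aryl Ring

The source may hold more compounds than are shown below. What is called first, only, known or untested is meant among the compounds shown, and "the series" means these compounds.

Compound 1 `Nc1cc(S(=O)(=O)c2ccccc2)c([N+](=O)[O-])c2cccnc12` gives 297 nM in an assay for binding affinity to Neuropeptide Y receptor type 1 (Homo sapiens), read by radioligand binding; a higher number here means a weaker inhibitor, a lower number a stronger inhibitor.
Compound 2 `Nc1cc(S(=O)(=O)c2cccc(Cl)c2)c([N+](=O)[O-])c2cccnc12` gives 892 nM in this assay.

Going by the values given here, of these two numbers in this assay, compound 2 holds the higher one, and its only neighbour is compound 1, separated by the step of a 3.0-fold higher number from compound 1 to compound 2 (0.48 log units; beyond the scatter). Compound 3 `Nc1cc(S(=O)(=O)c2ccccc2Cl)c([N+](=O)[O-])c2cccnc12` carries the change (2-chlorophenyl in place of 3-chlorophenyl on a sulfonyl sulfur). Among the compounds with values here, the one measured step bears only indirectly on it, since it adds a chlorine rather than relocating one, so the size of the step in this assay is expected to be modest and its direction uncertain. Compound 3 is therefore expected to give 600 nM, within a range from 150 nM to 2500 nM. The step from compound 2 to compound 3 is estimated at a 1.5-fold lower number from compound 2 to compound 3 (0.17 log units; within the scatter).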

Compound 3, inhibition constant: 93 nM
Estimate against measurement, compound 3: 6.5-fold (0.81 log units) above; measured number outside the range, below it.
By their numbers in this assay, from the lowest: compound 3; then compound 1; then compound 2.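

In this assay, the placement of the chlorine on this aryl ring on the sulfonyl sulfur matters: with the atoms unchanged, 2-chlorophenyl in place of 3-chlorophenyl gives a 9.6-fold lower number from compound 2 to compound 3 (0.98 log units; beyond the scatter) and turns the weakest of the three compounds into the strongest. Chloro in place of hydrogen therefore has no single direction here, since a 3.2-fold lower number from compound 1 to compound 3 (0.50 log units; beyond the scatter) runs opposite to a 3.0-fold higher number from compound 1 to compound 2 (0.48 log units; beyond the scatter) on the same core. Nothing available explains this difference between the two placements.

As far as these compounds go, whether a fluorine or a methoxy group, in the place the chlorine holds in 2-chlorophenyl, would behave likewise remains open.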